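A few compounds are considered here, and "the series" means these few. Any claim that something is new, unique, unknown or untested is made for them only; others in the source may bear on it.

Measured compounds:
compound 1, `Cc1cccc(Cc2nc3cc(O[C@H]4CC[C@@H](C(=O)O)CC4)ccc3n2C)c1`, 42 nM
compound 2, `Cc1cccc(Cn2nc3cc(O[C@H]4CC[C@@H](C(=O)O)CC4)ccc3c2C)c1`, 45 nM

These numbers come from an assay on isolated protein for inhibition of Long-chain-fatty-acid--CoA ligase 1 (Homo sapiens), read by mass spectrometry, with a stated time of 90 min, in the presence of a further agent that is not named here; a lower number here means a stronger inhibitor, a higher number a weaker inhibitor. In this assay compound 1 gives 42 nM, and compound 2 gives 45 nM. Compound 1 has the lowest of the two numbers, but compound 2 sits within the scatter of it, so the two values show no difference that can be relied on. Going by the values given here, no step between two measured compounds that differ in one place is available, so nothing here shows how a single change moves the number.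

The unmeasured compound 3, `Cn1c(Cc2cccnc2)nc2cc(O[C@H]3CC[C@@H](C(=O)O)CC3)ccc21`, differs from compound 1 in one place: pyridin-3-yl in place of 3-methylphenyl on a saturated chain carbon bound to an aromatic carbon. Put another way, the 3-methylbenzyl part of compound 1 gives way to a (pyridin-3-yl)methyl part, while the rest of the molecule, including the shared core, stays as it is. Among the compounds with values here, with no measured step of this kind to lean on, the expectation is a modest move toward a higher number, a step that may reach only a little beyond the scatter. For compound 3 the estimated step is a 2.9-fold higher number from compound 1 to compound 3 (0.46 log units; beyond the scatter). The expected value of compound 3 in this assay is 120 nM, with a range from 40 nM to 400 nM.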

Compound 3, half-maximal inhibitory concentration: 141000 nM
Beside the measured number, compound 3's estimate is 1200-fold (3.07 log units) below it; the measured number lies above the stated range.
By their numbers in this assay, from the lowest: compounds 1 and 2 (each within the scatter of the next); then compound 3.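

Going by these compounds alone, with a 3400-fold higher number from compound 1 to compound 3 (3.53 log units; beyond the scatter) in this assay, the group on the saturated chain carbon bound to an aromatic carbon proves to matter a great deal, which the earlier compounds could not show with no single-place step between them. The change looks small on paper: a six-membered aromatic ring stays in place, the group loses one heavy atom, and it gains one hydrogen-bond acceptor, yet the shared core and the carboxylic acid alone do not hold the number down once 3-methylphenyl has gone. No measurement offered here accounts for the size of this step.

The swap makes two changes at once, removing the methyl group and placing a nitrogen in the ring, so these compounds cannot say which of the two carries the loss. A plain phenyl group at this place would separate the two changes, and a methyl-bearing pyridine ring or a 3-chlorophenyl group would show whether the ring nitrogen can be tolerated or whether other groups can stand in for the methyl.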